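Removing the naphthyl ether from a sulfonamide triazole

The source may report more compounds than this note shows. Statements on the series, on what has been measured and on what is new or still open speak of the compounds shown alone.

Compound 1, `COc1cc2c(cc1OC)CN(S(=O)(=O)c1ccc(-n3cc(COc4ccc5ccccc5c4)nn3)cc1)CC2`, in an ADME assay on Vero cells (Chlorocebus sabaeus) for cytotoxicity, with a stated time of 4 days (a higher number here means a weaker inhibitor, a lower number a stronger inhibitor), compound 1 gives > 50 ug/mL, which is a limit of the assay and not a number.
Compound 2, `O=S(=O)(c1ccc(-n2cc(COc3ccc4ccccc4c3)nn2)cc1)N1CCc2ccccc2C1`, in this assay compound 2 gives > 50 ug/mL, likewise a limit.

Going by the values given here, compound 1 therefore stands at the limit, and the only other value shown sits there as well: the limit of > 50 ug/mL in this assay, at which 2 of the 2 values shown sit. Among the compounds with values here, nothing measured separates compound 1 from compound 2, so no step between them can be read.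

Compound 3, `COc1cc2c(cc1OC)CN(S(=O)(=O)c1ccc(-n3cc(CO)nn3)cc1)CC2`, has not yet been measured in this assay. It differs from compound 1 by hydrogen in place of naphthalen-2-yl on an oxygen on a saturated carbon. With both shown values at the limit, no step beyond the scatter is expected in this assay in either direction. For compound 3 the expected result is 60 ug/mL, within 30 ug/mL to 150 ug/mL, which is an expected step that the limit leaves unreadable from compound 1 to compound 3.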

Compound 3, half-maximal inhibitory concentration: > 50 ug/mL
Compound 3: no number, only a limit (the forecaster's own chance of this, stated with the estimate: 85%); the middle value lies beyond the limit too.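

In this assay compound 3 gives only a limit of the assay, as compound 1 does, so no step between compound 1 and compound 3 can be read: the limit of > 50 ug/mL in this assay, at which 3 of the 3 values shown sit.

The compounds shown leave open at what concentration any of them would reach half-maximal inhibition, and whether hydrogen in place of naphthalen-2-yl shifts that concentration at all.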